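This account rests on a few compounds, and the source may have more. Where it says the series, first, only, none or still open, it means among the compounds named here.

In a functional assay on HCT-116 cells (Homo sapiens) for antiproliferative activity, read by MTT assay, with a stated time of 48 h (on this read-out lower numbers stand for stronger inhibition and higher numbers for weaker inhibition), the measured compounds stand as follows
- compound 1 `COc1cc(-c2nnc3c(OC4COC4)cc(-c4ccc5[nH]ccc5c4)cn23)cc(OC)c1OC` gives 5370 nM
- compound 2 `COc1cc(-c2nnc3c(OC4COC4)cc(-c4ccc5c(ccn5C)c4)cn23)cc(OC)c1OC` gives 1290 nM

Compound 2 holds the lower of the two numbers in this assay (1290 nM). Compound 3 `CCCN1CC(Oc2cc(-c3ccc4c(ccn4C)c3)cn3c(-c4cc(OC)c(OC)c(OC)c4)nnc23)C1` carries 1-propylazetidin-3-yl in place of oxetan-3-yl on an oxygen on an aromatic ring. Among the compounds with values here, the one measured step (a 4.2-fold lower number from compound 1 to compound 2 (0.62 log units; beyond the scatter)) is modest, but it comes from methyl in place of hydrogen on an aromatic nitrogen, a different place. Within the data shown here, it bears only loosely on this change, and no measured step shows a direction here. A small step is therefore expected, tentatively downward (a 1.4-fold lower number from compound 2 to compound 3 (0.16 log units; within the scatter)). Compound 3 is estimated at 900 nM (expected range 280 nM to 3000 nM).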

Compound 3, half-maximal inhibitory concentration: 675 nM
The estimate for compound 3 lay 1.3-fold (0.12 log units) above the measured number, within the range that was stated.
By their numbers in this assay, from the lowest: compounds 3 and 2 (each within the scatter of the next); then compound 1.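

In this assay, within the data shown here, 1-propylazetidin-3-yl in place of oxetan-3-yl on an oxygen on an aromatic ring gives a 1.9-fold lower number from compound 2 to compound 3 (0.28 log units; within the scatter), the first reading at this position. The position thus accepts a group with three more heavy atoms, including a ring nitrogen and a propyl chain, while the two numbers stay within the scatter of each other. The compounds shown leave open what the ring nitrogen and the propyl chain each contribute, which azetidin-3-yl or 1-methylazetidin-3-yl on the same oxygen could separate. No measurement at hand offers an explanation for this result.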